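From 4-methylphenyl to 4-fluorophenyl in a small series

The source may hold more compounds than are shown below. What is called first, only, known or untested is meant among the compounds shown, and "the series" means these compounds.

Values in a functional assay on A549 cells (Homo sapiens) for antiproliferative activity, read by MTT assay, with a stated time of 72 h; a higher number here means a weaker inhibitor, a lower number a stronger inhibitor:
compound 1 `COc1cc(-n2cnc3ccc(-c4ccc(C)cc4F)cc32)cc(OC)c1OC`: > 10000 nM
compound 2 `COc1cc(-n2cnc3ccc(-c4cccc(Cl)c4)cc32)cc(OC)c1OC`: 7050 nM
compound 3 `COc1cc(-n2cnc3ccc(-c4ccc(C)cc4)cc32)cc(OC)c1OC`: 1940 nM

Compound 1 gives > 10000 nM, and that value is a limit of the assay, not a number. Among the compounds with values here, of the two true numbers, compound 3 holds the lower at 1940 nM, and the only other number belongs to compound 2 at 7050 nM.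

Compound 4 `COc1cc(-n2cnc3ccc(-c4ccc(F)cc4)cc32)cc(OC)c1OC` has not yet been measured in this assay. Its difference from compound 3 is fluoro in place of methyl on an aromatic carbon, which is fluoro in place of methyl on an aromatic carbon, para to a large group. Within the data shown here, no measured pair makes this exact exchange, so two steps bear on it only indirectly. Hydrogen in place of fluoro gave an at least 5.1-fold lower number from compound 1 to compound 3 (0.71 log units; beyond the scatter). 4-methylphenyl in place of 3-chlorophenyl gave a 3.6-fold lower number from compound 2 to compound 3 (0.56 log units; beyond the scatter). Both steps end at compound 3, and neither of the other two compounds reaches a lower number. Taking these two steps as the guide, a modest rise in the number is expected rather than a fall. The expected step is a 1.8-fold higher number from compound 3 to compound 4 (0.26 log units; within the scatter). For compound 4 the estimate is 3500 nM, with an expected range from 1400 nM to 9000 nM.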

Compound 4, half-maximal inhibitory concentration: 6740 nM
Compound 4: the middle estimate sits 1.9-fold (0.28 log units) below what was measured, and the stated range covers the measured number.
By their numbers in this assay, from the lowest: compound 3; then compounds 4 and 2 (each within the scatter of the next). At a limit, above all of these: compound 1.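

In this assay, within the data shown here, fluoro in place of methyl on an aromatic carbon, para to a large group, gave a 3.5-fold higher number from compound 3 to compound 4 (0.54 log units; beyond the scatter), the first direct reading of an exchange at this position, and it favours methyl over fluoro. The 4-fluorophenyl in place of 3-chlorophenyl then gave a 1.0-fold lower number from compound 2 to compound 4 (0.02 log units; within the scatter), which leaves those two compounds indistinguishable, while compound 3, with its 4-methylphenyl, stands apart from both beyond the scatter. The step of an at least 1.4-fold lower number from compound 1 to compound 4 (0.17 log units; that floor lies within the scatter) rests on a limit rather than a number and gives no true size for that exchange: the limit of > 10000 nM in this assay, at which 1 of the 4 values shown sits.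

With only methyl and fluoro compared directly at this position, the compounds shown leave open whether the lower number of compound 3 is particular to methyl or would also appear with a methoxy, an amine or a longer chain in the same place. They also leave open whether the gap between methyl and fluoro would persist on a changed core or in cells other than A549.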